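Series notes: aryl-methyl amide swap, compound 2 to compound 3

The source may hold more compounds than are shown below. What is called first, only, known or untested is meant among the compounds shown, and "the series" means these compounds.

Two amides in this series have been run in an assay for displacement of a labelled ligand from Adrenergic receptor alpha-1 (Rattus norvegicus), with a stated time of 50 min; on this read-out lower numbers stand for stronger inhibition and higher numbers for weaker inhibition. Compound 1 `O=C(CCCCCN1CCN(c2ncccc2-c2ccncc2)CC1)NCc1ccc(F)nc1` gives 255 nM in this assay. Compound 2 `O=C(CCCCCN1CCN(c2cccnc2-c2ccncc2)CC1)NCc1ccc(F)nc1` gives 414 nM in this assay. Going by the values given here, on the two numbers so far, compound 2 stands alongside compound 1: the gap between them is within the usual scatter of repeated measurements, so the two cannot be ranked against each other, and compound 2 is not separated from compound 1.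

Compound 3 `COc1ccc(CNC(=O)CCCCCN2CCN(c3cccnc3-c3ccncc3)CC2)cc1` is not yet measured in this assay. It differs from compound 2 by 4-methoxyphenyl in place of 6-fluoropyridin-3-yl on a saturated chain carbon bound to an amide-type nitrogen. The shared core and the six-carbon amide chain are unchanged. Among the compounds with values here, no pair of measured compounds shows this change, so its size is not known from the series.

With nothing in the data to point in either direction, the step from compound 2 to compound 3 is expected to be a 1.1-fold lower number from compound 2 to compound 3 (0.04 log units; within the scatter), that is, no step beyond the scatter. The estimate for compound 3 in this assay is 380 nM, with a range from 120 nM to 1200 nM.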

Compound 3, inhibition constant: > 1000 nM
Compound 3: only a limit was reported (the forecaster's own chance of this, stated with the estimate: 3%); at least 2.6-fold (0.42 log units) between middle value and limit.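

Notes on the amide aryl group: compound 1 and compound 2 carry the same 6-fluoropyridin-3-yl group, so they said nothing about how much this place matters. In this assay, 4-methoxyphenyl in place of 6-fluoropyridin-3-yl on a saturated chain carbon bound to an amide-type nitrogen gives an at least 2.4-fold higher number from compound 2 to compound 3 (0.38 log units; beyond the scatter), which shows that this place is not indifferent to the aryl group, even though the two groups match in hydrogen-bond donors and acceptors and neither carries a net charge. The value of compound 3, > 1000 nM, is a limit and not a number, so the step has a floor but no known full size: the limit of > 1000 nM in this assay, at which 1 of the 3 values shown sits.

The change swaps the ring nitrogen and the fluorine for a carbon-only ring and a methoxy group in one step, so the compounds shown do not tell which part of it matters; a phenyl, 4-fluorophenyl or 6-methoxypyridin-3-yl group at this place would separate these parts. From the compounds shown here alone, it also remains open whether the same swap on the core of compound 1 would give a step of similar size.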